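Chain to ring at the amino nitrogen of a nucleoside

This account rests on a few compounds, and the source may have more. Where it says the series, first, only, none or still open, it means among the compounds named here.

Three close analogues share one core. Compound 1 `CNc1nc(SCc2ccc([N+](=O)[O-])cc2)c2ncn([C@@H]3O[C@H](CO)[C@@H](O)[C@H]3O)c2n1` carries a methyl on the nitrogen on the aromatic ring; in an assay on K562 cells for displacement of a labelled ligand from Equilibrative nucleoside transporter 1 (Homo sapiens), read by flow cytometry, with a stated time of 45 min (on this read-out higher numbers stand for weaker inhibition and lower numbers for stronger inhibition), compound 1 gives 24 nM. Compound 2 `CCCNc1nc(SCc2ccc([N+](=O)[O-])cc2)c2ncn([C@@H]3O[C@H](CO)[C@@H](O)[C@H]3O)c2n1` carries a propyl there, and in this assay compound 2 gives 193 nM. Compound 3 `CCCCNc1nc(SCc2ccc([N+](=O)[O-])cc2)c2ncn([C@@H]3O[C@H](CO)[C@@H](O)[C@H]3O)c2n1` carries a butyl, and in this assay compound 3 gives 325 nM. Compound 3 thus shows the highest number of the three, though its gap to compound 2 lies within the scatter; only the gap to compound 1 is beyond it.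

The steps on record are an 8.0-fold higher number from compound 1 to compound 2 (0.91 log units; beyond the scatter), a 14-fold higher number from compound 1 to compound 3 (1.13 log units; beyond the scatter) and a 1.7-fold higher number from compound 2 to compound 3 (0.23 log units; within the scatter). The first two are sizeable; the third, adding one carbon to an already extended chain, is not.

Compound 4 `O=[N+]([O-])c1ccc(CSc2nc(NC3CCC3)nc3c2ncn3[C@@H]2O[C@H](CO)[C@@H](O)[C@H]2O)cc1` differs from compound 3 by cyclobutyl in place of butyl on a nitrogen on an aromatic ring. Among the compounds with values here, no measured step folds a chain into a ring, so the closest guide is the small step from propyl to butyl. Because a 1.7-fold higher number from compound 2 to compound 3 (0.23 log units; within the scatter) was within the scatter, compound 4 is expected to show a 1.3-fold lower number from compound 3 to compound 4 (0.11 log units; within the scatter), that is no change beyond the scatter. Compound 4 is therefore estimated at 250 nM, within 90 nM to 700 nM.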

Compound 4, inhibition constant: 33 nM
For compound 4 the middle estimate is 7.6-fold (0.88 log units) above the measured one; the measured number lies below the stated range.
By their numbers in this assay, from the lowest: compounds 1 and 4 (each within the scatter of the next); then compounds 2 and 3 (each within the scatter of the next).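

In this assay, closing the same carbons into a ring gives a 9.8-fold lower number from compound 3 to compound 4 (0.99 log units; beyond the scatter), which shows that on this nitrogen on an aromatic ring the shape of the group matters, not just its count of heavy atoms: butyl and cyclobutyl have the same count, yet their numbers lie well apart. Compound 4 also parts from propyl, with a 5.8-fold lower number from compound 2 to compound 4 (0.77 log units; beyond the scatter), while a 1.4-fold higher number from compound 1 to compound 4 (0.14 log units; within the scatter) leaves it level with the methyl compound, so a larger group here need not bring the higher number seen for compounds 2 and 3, and compound 4 goes against that trend. Nothing on hand explains why the ring and the open chain differ in this way.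

The compounds shown leave open whether this result belongs to the four-membered ring alone or extends to cyclopropyl or cyclopentyl, and whether a branched chain such as isobutyl would fall with butyl or with cyclobutyl. They also leave open whether the difference between ring and chain would persist if a group such as an amine replaced the nitro group elsewhere on the shared core.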